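A Cyclopropylamine Gives Way to a Primary Alcohol

The compounds below may be only part of what the source reports. "The series", "measured", "known", "first", "only" and "open" are said of these compounds alone.

Measured compounds:
- compound 1 `COc1cc(Oc2cccc(Nc3ccccc3)c2)cc(OC)c1CNCc1ccc(Br)cc1`: in a functional assay on HCT-116 cells (Homo sapiens) for inhibition, read by MTT assay, with a stated time of 72 h (a lower number here means a stronger inhibitor, a higher number a weaker inhibitor), compound 1 gives 6230 nM
- compound 2 `COc1cc(Oc2cccc(Nc3ccccc3)c2)cc(OC)c1CNC1CC1`: in this assay compound 2 gives > 20000 nM, which is a limit of the assay and not a number

Both compounds share a core and differ only at the amine nitrogen. Among the compounds with values here, the one measured step, an at least 3.2-fold higher number from compound 1 to compound 2 (0.50 log units; beyond the scatter), places compound 2 at the weak end of what the assay can report; here the limit of > 20000 nM in this assay, at which 1 of the 2 values shown sits, marks where compound 2 sits, so only a floor on its number is known.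

Compound 3 `COc1cc(Oc2cccc(Nc3ccccc3)c2)cc(OC)c1CCO` has not yet been measured. It differs from compound 2 by hydroxymethyl in place of cyclopropylamino on a saturated chain carbon bound to an aromatic carbon. The measured step from compound 1 to compound 2 bears on this only loosely, since it concerns the group on the amine nitrogen, whereas the new change removes that nitrogen altogether and puts an alcohol in its place. Nothing among the two values shown suggests a return toward the number of compound 1. Compound 3 is therefore expected to stay near the limit, and the step expected is a step that the limit leaves unreadable from compound 2 to compound 3. Compound 3 is estimated at 30000 nM, within a range from 9000 nM to 100000 nM.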

Compound 3, half-maximal inhibitory concentration: > 20000 nM
Compound 3: only a limit was reported (the forecaster's own chance of this, stated with the estimate: 70%); the middle value does not contradict the limit.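

With hydroxymethyl at this saturated chain carbon, the amine nitrogen is gone altogether, and this assay gives an at least 3.2-fold higher number from compound 1 to compound 3 (0.50 log units; beyond the scatter). The earlier compounds shown here showed only that replacing 4-bromobenzyl with cyclopropyl on the amine nitrogen moved the number to the limit; this result shows that a compound without that nitrogen also fails to reach a readable number. The step from compound 2 to compound 3 cannot be read, and no order between cyclopropylamino and hydroxymethyl can be stated, but the weak end of the assay now holds both compounds: the limit of > 20000 nM in this assay, at which 2 of the 3 values shown sit.

Within the data shown here, compound 1 remains the only compound here with a readable number, which leaves open whether that number depends on the amine nitrogen, the 4-bromobenzyl group, or both together. An unsubstituted benzyl group on the same nitrogen could begin to separate these, while a carboxylic acid or a longer chain in place of the hydroxymethyl would show whether any group without an amine can bring the number back within the range of the assay.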